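A few compounds are considered here, and "the series" means these few. Any claim that something is new, unique, unknown or untested is made for them only; others in the source may bear on it.

Measured compounds:
Compound 1, `CC(=O)n1cc(/C=C(/C(=O)O)c2ccccc2)c2cc(OCc3ccccc3)ccc21`, gives in a functional assay on LNCaP cells (Homo sapiens) for cytotoxicity, read by MTT assay, with a stated time of 72 h (on this read-out higher numbers stand for weaker inhibition and lower numbers for stronger inhibition), a value of > 100000 nM, which is a limit of the assay rather than a number.
Compound 2, `CC(=O)n1cc(/C=C(/C(=O)O)c2ccc(OCc3ccccc3)cc2)c2cc(OCc3ccccc3)ccc21`, gives in this assay 77700 nM.
Compound 3, `COc1ccc(Cn2cc(/C=C(/C(=O)O)c3ccccc3)c3cc(OCc4ccccc4)ccc32)cc1`, gives in this assay 38200 nM.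

Compound 1 thus stands only at the limit of > 100000 nM in this assay, at which 1 of the 3 values shown sits, and both other compounds sit at lower numbers: an at least 1.2-fold lower number from compound 1 to compound 2 (0.10 log units; that floor lies within the scatter), and an at least 2.6-fold lower number from compound 1 to compound 3 (0.41 log units; beyond the scatter).

Compound 4, `COc1ccccc1/C(=C\c1cn(C(C)=O)c2ccc(OCc3ccccc3)cc12)C(=O)O`, is not yet measured. It differs from compound 1 by methoxy in place of hydrogen on an aromatic carbon, the new group sitting ortho to a large group on that ring. Both measured steps start from compound 1 and add a group somewhere on the molecule. The one that sits on the same phenyl ring, the addition of benzyloxy, moved the number only a little, an at least 1.2-fold lower number from compound 1 to compound 2 (0.10 log units; that floor lies within the scatter), whereas the exchange at the aromatic nitrogen gave the larger shift, an at least 2.6-fold lower number from compound 1 to compound 3 (0.41 log units; beyond the scatter). A methoxy on the phenyl ring is closer in kind to the first of these, so for compound 4 the expectation is a step of a number no higher from compound 1 to compound 4 (the limit leaves the size open), that is, no change beyond the scatter, with the outcome possibly again reported as a limit. Compound 4 is therefore estimated at 100000 nM, within a range of 40000 nM to 250000 nM.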

Compound 4, half-maximal inhibitory concentration: 48500 nM
For compound 4 the middle estimate is 2.1-fold (0.31 log units) above the measured one, within the range that was stated.
By their numbers in this assay, from the lowest: compounds 3, 4 and 2 (each within the scatter of the next, the first and the last beyond it). At a limit, above all of these: compound 1.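

In this assay, the change from phenyl to 2-methoxyphenyl gives a step whose floor lies beyond the scatter, which the benzyloxy addition on this ring did not show: an at least 2.0-fold lower number from compound 1 to compound 4 (0.31 log units; beyond the scatter). So a change on this phenyl ring, with the acetyl on the aromatic nitrogen left in place, can be enough on its own to turn a limit into a measured value, and methoxy, with its 2 heavy atoms, does this at the place ortho to a large group. The step gives only a floor and not a full size because of where compound 1 stands: the limit of > 100000 nM in this assay, at which 1 of the 4 values shown sits.

Going by these compounds, whether methoxy at another place on the phenyl ring would give a similar number stays open, as does whether a different group at this same place, such as an amine, a hydroxyl or a longer ether chain, would do the same. Also open, on these data alone, is whether this methoxy and the 4-methoxybenzyl on the aromatic nitrogen, seen so far only in separate compounds, would lower the number further when combined in one molecule.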